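From 4-Methylphenyl to Benzyl on a Ring Nitrogen

The source may hold more compounds than are shown below. What is called first, only, known or untested is meant among the compounds shown, and "the series" means these compounds.

Of the compounds shown here, two sharing one core have so far been tested in a functional assay on HeLa cells (Homo sapiens) for antiproliferative activity, read by CCK-8 assay, with a stated time of 72 h, tested at 2 uM; a higher number here means a stronger effect of the compound at the concentration tested, a lower number a weaker effect. Compound 1 `Nc1ccccc1NC(=O)c1ccc(CSC(=S)N2CCN(Cc3ccccn3)CC2)cc1` carries a (pyridin-2-yl)methyl group on an amine nitrogen in a ring, and in this assay compound 1 gives 14.2%. Compound 2 `Cc1ccc(N2CCN(C(=S)SCc3ccc(C(=O)Nc4ccccc4N)cc3)CC2)cc1` carries 4-methylphenyl in the same place, and compound 2 gives 25.3%. Among the measured compounds shown here, the one step between them is a number 11.1 percentage points higher from compound 1 to compound 2 (beyond the scatter), so compound 2 stands highest of the two numbers, with compound 1 its only neighbour.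

Compound 3 `Nc1ccccc1NC(=O)c1ccc(CSC(=S)N2CCN(Cc3ccccc3)CC2)cc1` has not been measured. Against compound 2 the change is benzyl in place of 4-methylphenyl on an amine nitrogen in a ring. For the measured compounds named here, the only step that bears on this is a number 11.1 percentage points higher from compound 1 to compound 2 (beyond the scatter), where 4-methylphenyl replaced (pyridin-2-yl)methyl. Benzyl resembles both groups at once: it keeps the carbon-only ring of compound 2 while being joined like the group of compound 1. A modest downward shift, or none beyond the scatter, is therefore expected. For compound 3 the expected value in this assay is 20%, within a range from 8% to 32%. This estimate implies a number 5.3 percentage points lower from compound 2 to compound 3 (within the scatter), expected to be small.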

Compound 3, a percentage reported as inhibition, at one concentration (the size of the read-out at that concentration, not a potency): 20.6%
For compound 3 the middle estimate is 0.6 percentage points below the measured one; the range from low to high includes it.
By their numbers in this assay, from the lowest: compounds 1, 3 and 2 (each within the scatter of the next, the first and the last beyond it).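

In this assay, benzyl in place of 4-methylphenyl on the ring nitrogen gives a number 4.7 percentage points lower from compound 2 to compound 3 (within the scatter), so these two groups, made of the same atoms joined differently, cannot be told apart at this position. The other new comparison keeps the link to the ring nitrogen and swaps only the aromatic ring, phenyl in place of pyridin-2-yl, and gives a number 6.4 percentage points higher from compound 1 to compound 3 (within the scatter); the earlier gap, a number 11.1 percentage points higher from compound 1 to compound 2 (beyond the scatter), therefore spans two changes that each stay within the scatter when taken alone, which leaves compound 3 unresolved from both of its neighbours. No supporting evidence is available to explain any of these differences.

Still open is how an unsubstituted phenyl placed directly on the ring nitrogen, or a longer chain such as 2-phenylethyl, would read in this assay, and whether either would move the number clearly away from the three shown here. All three numbers also come from a single concentration, so they describe the size of the effect at that concentration and leave potency unknown.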